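Replacing Phenyl by tert-Butyl on the Core of Compound 1

A few compounds are considered here, and "the series" means these few. Any claim that something is new, unique, unknown or untested is made for them only; others in the source may bear on it.

Compound 1, `CN1CCN(CCNCc2cn(-c3ccc(F)cc3F)nc2-c2ccccc2)CC1`: in an ADME assay on Huh-7 cells (Homo sapiens) for cytotoxicity (a lower number here means that less compound is tolerated, a higher number that more compound is tolerated), compound 1 sits at a limit of the assay, > 20000 nM, not at a number.
Compound 2, `CCCN1CCC(CNCc2cn(-c3ccc([N+](=O)[O-])cc3)nc2-c2ccc(Cl)cc2)CC1`: in this assay compound 2 gives 11000 nM.
Compound 3, `CCCN1CCC(CNCc2cn(-c3ccc(C(F)(F)F)cc3)nc2-c2ccc(OC(F)(F)F)cc2)CC1`: in this assay compound 3 gives 2200 nM.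

Compound 1 stands at the top of what the three measured compounds show: its value is a limit, (the limit of > 20000 nM in this assay, at which 1 of the 3 values shown sits), so it is known only that more of it is tolerated than the assay can resolve. Within the data shown here, compounds 2 and 3 give numbers rather than limits, but each of them differs from compound 1 in several places at once, so no single step between measured compounds can be read off.

Compound 4, `CN1CCN(CCNCc2cn(-c3ccc(F)cc3F)nc2C(C)(C)C)CC1`, differs from compound 1 in one place: tert-butyl in place of phenyl on an aromatic carbon. Among the measured compounds shown here, nothing among the measured compounds isolates this change, so the account can only carry the limit forward. In this assay the step is expected to be none beyond the scatter, and the estimate gives a number no higher from compound 1 to compound 4 (the limit leaves the size open). Compound 4 is therefore estimated at 20000 nM, with a range from 8000 nM to 40000 nM, and it may well again be reported only as a limit.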

Compound 4, half-maximal cytotoxic concentration: > 20000 nM
Compound 4 was reported as a limit; the forecaster's own chance of this, stated with the estimate: 60%; the middle value lies on the limit itself.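

In this assay compound 4 gives > 20000 nM, which is a limit, and compound 1 is also known only as a limit, so the swap of phenyl for tert-butyl yields no readable step between compound 1 and compound 4: the limit of > 20000 nM in this assay, at which 2 of the 4 values shown sit. The compounds shown leave open how much of either compound is actually tolerated, and whether the two differ at all.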